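This account rests on a few compounds, and the source may have more. Where it says the series, first, only, none or still open, it means among the compounds named here.

Compound 1 `CCC(CC)=NNc1nc(-c2cccc([N+](=O)[O-])c2)cs1` was tested in an assay on isolated protein for inhibition of Amine oxidase [flavin-containing] B (Homo sapiens), read by fluorescence, with a stated time of 20 min (on this read-out lower numbers stand for stronger inhibition and higher numbers for weaker inhibition), and gave 53 nM. Compound 2 `C=CCC/C(C)=N\Nc1nc(-c2cccc([N+](=O)[O-])c2)cs1` gave 101 nM in this assay. Among the compounds with values here, the only measured step, a 1.9-fold higher number from compound 1 to compound 2 (0.28 log units; within the scatter), lies within the usual scatter, so compound 1 stands at the lower end of two numbers that cannot really be told apart. Compound 3 `CCCCC/C(CC)=N\Nc1nc(-c2cccc([N+](=O)[O-])c2)cs1` has not yet been measured; it differs from compound 1 by propyl in place of hydrogen on a saturated chain carbon, two bonds along the chain from a carbon with a double bond to nitrogen. Within the data shown here, the one measured step also lengthened this chain and stayed within the scatter, giving no reason to expect a change beyond it here. Compound 3 is therefore expected to sit near 90 nM, within 30 nM to 270 nM. That amounts to an expected step of a 1.7-fold higher number from compound 1 to compound 3 (0.23 log units; within the scatter).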

Compound 3, half-maximal inhibitory concentration: 355 nM
Compound 3: middle estimate off by 3.9-fold (0.60 log units), on the low side, and the stated range ends below it.
By their numbers in this assay, from the lowest: compounds 1 and 2 (each within the scatter of the next); then compound 3.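

In this assay, propyl in place of hydrogen on a saturated chain carbon, two bonds along the chain from a carbon with a double bond to nitrogen, gives a 6.7-fold higher number from compound 1 to compound 3 (0.83 log units; beyond the scatter). So this position does not accept every added chain without a loss: the added propyl weakens inhibition beyond the scatter, whereas the earlier change stayed within it. No measurement here explains this loss. Open, as far as these compounds go, is whether a single methyl at this position would keep the number close to that of compound 1, and how an amine or a hydroxyl group there would behave.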